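From Hexenyloxy to Phenylsulfonyl on Compound 1

The source may hold more compounds than are shown below. What is called first, only, known or untested is meant among the compounds shown, and "the series" means these compounds.

In a functional assay on U-373MG ATCC cells (Homo sapiens) for inhibition, read by colorimetric assay and MTT assay, with a stated time of 72 h (on this read-out lower numbers stand for stronger inhibition and higher numbers for weaker inhibition), compound 1 (`C=CCCCCOc1ccccc1-c1cnc(OCCCCC=C)n1C`) gives 7000 nM. Among the measured compounds shown here, compound 2 (`C=CCCCCOc1ncc(-c2ccccc2OC)n1C`) gives 9000 nM, so only two numbers are available so far. For the measured compounds named here, the single measured step between them is a 1.3-fold higher number from compound 1 to compound 2 (0.11 log units; within the scatter). These two compounds therefore stand level. For compound 3 (`COc1ccccc1-c1cnc(OCCCc2ccccc2)n1C`) the entry reads "not determined" (no result reported), which adds no number.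

Compound 4 (`C=CCCCCOc1ccccc1-c1cnc(S(=O)(=O)c2ccccc2)n1C`) changes the core of compound 1 at a different place: phenylsulfonyl in place of (hex-5-en-1-yl)oxy on an aromatic carbon. In words, phenylsulfonyl sits in place of (hex-5-en-1-yl)oxy on an aromatic carbon. Going by the values given here, no measured step touches that carbon, because a 1.3-fold higher number from compound 1 to compound 2 (0.11 log units; within the scatter) concerns the other oxygen-bound chain. That step offers only a weak guide, and the data give no direction for the new group. With nothing pointing up or down, the estimated step is a 1.1-fold higher number from compound 1 to compound 4 (0.06 log units; within the scatter), so no shift beyond the scatter is expected, although the uncertainty is wide. Compound 4 is estimated at 8000 nM, with an expected range from 2500 nM to 25000 nM.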

Compound 4, half-maximal inhibitory concentration: 63000 nM
Compound 4: the middle estimate sits 7.9-fold (0.90 log units) below what was measured; measured number above the stated range.
By their numbers in this assay, from the lowest: compounds 1 and 2 (each within the scatter of the next); then compound 4.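

The aromatic carbon between two ring nitrogen atoms is sensitive to what it carries. In this assay, among the compounds shown here, placing phenylsulfonyl there instead of (hex-5-en-1-yl)oxy gives a 9.0-fold higher number from compound 1 to compound 4 (0.95 log units; beyond the scatter), the first change in this set that clearly weakens inhibition. For the compounds shown here, the only earlier step, a 1.3-fold higher number from compound 1 to compound 2 (0.11 log units; within the scatter), altered the other oxygen-bound chain and gave no information about this carbon, and no available data explain the loss seen here.

This one swap removes a flexible chain and its oxygen link while adding a sulfonyl group and a phenyl ring, so the compounds shown cannot separate these changes. A phenoxy group or a methylsulfonyl group at this carbon could show whether the loss follows the sulfonyl group or the phenyl ring.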